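Replacing allyloxy with bromo in an antiproliferative series

A few compounds are considered here, and "the series" means these few. Any claim that something is new, unique, unknown or untested is made for them only; others in the source may bear on it.

Compound 1 `CCCNNC(=O)c1ccc(CNC(=O)c2cc3ccccc3cn2)cc1` gives 45.9 nM
Compound 2 `C=CCOc1ccc2oc(C(=O)NCc3ccc(C(=O)NNCCC)cc3)cc2c1` gives 53.8 nM

Both values come from a functional assay on MV4-11 cells (Homo sapiens) for antiproliferative activity, with a stated time of 48 h (on this read-out lower numbers stand for stronger inhibition and higher numbers for weaker inhibition), and lie within the usual scatter of each other, so compound 2 stands level with compound 1 on these numbers.

Compound 3 `CCCNNC(=O)c1ccc(CNC(=O)c2cc3cc(Br)ccc3o2)cc1` has not yet been measured. Compared with compound 2, it carries bromo in place of allyloxy on an aromatic carbon of a six-membered aromatic ring of carbon only bromo in place of allyloxy on an aromatic carbon as its single change.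

For the measured compounds named here, no two measured compounds differ in one place, so no measured step shows the size of such a change. The expectation rests only on compound 1 at 45.9 nM and compound 2 at 53.8 nM which stay close despite their different structures. The change a 1.1-fold lower number from compound 2 to compound 3 (0.03 log units; within the scatter) is expected to stay within the scatter, with no direction favoured. In this assay compound 3 is estimated at 50 nM with an expected range from 20 nM to 125 nM for repeated measurements.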

Compound 3, half-maximal inhibitory concentration: 159 nM
Compound 3: middle estimate off by 3.2-fold (0.50 log units), on the low side, outside the stated range (above it).
By their numbers in this assay, from the lowest: compounds 1 and 2 (each within the scatter of the next); then compound 3.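

In this assay, for the compounds shown here, the exchange of allyloxy for bromo gives a 3.0-fold higher number from compound 2 to compound 3 (0.47 log units; beyond the scatter) and is the only single-place step that can be read in this set. It shows that this position, on a six-membered aromatic ring of carbon only, is not indifferent to its group: allyloxy, with its 4 heavy atoms, cannot be replaced by a single bromine atom without weaker inhibition beyond the scatter. No measurement available here bears on what lies behind this step.

The compounds shown leave open which part of allyloxy matters, since a methoxy, a propoxy or a hydroxy group at this place would separate the oxygen from the chain and its double bond. They also leave open whether an amine here would stand level with compound 2 or with compound 3.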